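A few compounds are considered here, and "the series" means these few. Any claim that something is new, unique, unknown or untested is made for them only; others in the source may bear on it.

Measured so far:
- Compound 1 `CCOc1cc(Cl)c(C(=O)NC(=O)Nc2nc3ccc(S(=O)(=O)C4CCN(C)CC4)cc3s2)cc1-n1cccn1` gives 200 nM
- Compound 2 `CCOc1cc(Cl)c(C(=O)Nc2nc3ccc(S(=O)(=O)CCCN4CCN(C)CC4)cc3s2)cc1N1C[C@H](C)O[C@@H](C)C1` gives 155000 nM

In a physicochemical assay for solubility (on this read-out lower numbers stand for lower solubility and higher numbers for higher solubility), compound 2 stands at 155000 nM as the higher of the two numbers, and compound 1 gives 200 nM, a gap beyond the scatter. These two compounds differ in more than one place, so that gap cannot be assigned to any single structural change.

Compound 3 `CCOc1cc(Cl)c(C(=O)Nc2nc3ccc(S(=O)(=O)CCCN4CCN(C)CC4)cc3s2)cc1N1C[C@@H](C)O[C@@H](C)C1` is the next to be read. The change is small: the two compounds have the same atoms and bonds and differ only in configuration as drawn: 1 of 2 stereo elements differ; a stereocentre at a saturated ring carbon is drawn S in compound 2 and R in compound 3 and a stereocentre at a saturated ring carbon is drawn S in compound 2 and R in compound 3. The two compounds have the same atoms and bonds. Going by the values given here, no measured pair shows what such a change does in this assay so any expectation here is a cautious one. With nothing else altered, no step beyond the scatter is expected, and compound 3 should stay close to compound 2 at 155000 nM on this read-out. The estimated move is small: a 1.1-fold lower number from compound 2 to compound 3 (0.04 log units; within the scatter) is expected to remain within the scatter. The expected value for compound 3 is 140000 nM with an estimated range from 60000 nM to 300000 nM in this measurement.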

Compound 3, solubility: 95000 nM
Beside the measured number, compound 3's estimate is 1.5-fold (0.17 log units) above it, within the range that was stated.
By their numbers in this assay, from the lowest: compound 1; then compounds 3 and 2 (each within the scatter of the next).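

In this assay, going by these compounds alone, the step for this change is a 1.6-fold lower number from compound 2 to compound 3 (0.21 log units; within the scatter), the first measured pair in which only one structural feature varies. Compound 2 and compound 3 therefore give this series its first reading at a stereocentre on a saturated ring carbon, and the reading can be tied to a single place: the fact that compounds 2 and 3 differ only in the configuration as drawn. With the step inside the scatter, this pair gives no ground for separating the two drawn configurations on this read-out, although it covers only this one inversion, with the rest of the structure held as it is in compound 2.

The pair says nothing about what replacing the ring bearing this stereocentre would do, or about how the step would read if that ring carried a carboxylic acid or a primary amine in place of a methyl group. Within the data shown here, it also leaves unassigned the wide gap between compound 1 and compound 2, since those two compounds differ in more than one place and no measured single-place steps yet connect them, whether through the chain carrying the methylpiperazine or through the carbonyl-containing link to the core.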